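This account rests on a few compounds, and the source may have more. Where it says the series, first, only, none or still open, it means among the compounds named here.

Measured in an ADME assay on HUVEC cells (Homo sapiens) for cytotoxicity, read by MTT assay, with a stated time of 24 h; on this read-out lower numbers stand for stronger inhibition and higher numbers for weaker inhibition:

- compound 1 `COc1cc(C2Oc3cc(-c4oc5cc(O)cc(O)c5c(=O)c4O)ccc3OC2CO)ccc1OC(=O)c1cc(O)c(O)c(O)c1`: 4300 nM
- compound 2 `COc1cc(C2Oc3cc(-c4oc5cc(O)cc(O)c5c(=O)c4OC(=O)c4cc(O)c(O)c(O)c4)ccc3OC2CO)ccc1O`: 18900 nM
- compound 3 `COCC1Oc2ccc(-c3oc4cc(O)cc(O)c4c(=O)c3OC)cc2OC1c1ccc(O)c(OC)c1`: 60900 nM

Of these three, compound 3 has the highest number, so it is the least toxic to the cells in this assay. Compound 2 comes closest to it, and compound 1 lies furthest away. The gaps to both go beyond the usual scatter of repeat measurements.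

The next structure is compound 4 `COCC1Oc2ccc(-c3oc4cc(O)cc(O)c4c(=O)c3O)cc2OC1c1ccc(O)c(OC)c1`. It differs from compound 3 by one small edit: hydrogen in place of methyl on an oxygen on an aromatic ring. A hydrogen takes the place of methyl on an oxygen on an aromatic ring, turning a methoxy into a hydroxy.

Among the measured compounds shown here, no measured pair isolates this edit, so the evidence is indirect. Compound 1 also has a hydrogen on that oxygen and gives 4300 nM, but it differs from compound 3 in other places too. That value therefore suggests a direction and only loosely a size. A moderate move toward a lower number is expected, with the estimated change being a 2.4-fold lower number from compound 3 to compound 4 (0.39 log units; beyond the scatter). The estimated value for compound 4 is 25000 nM, with an expected range from 9000 nM to 70000 nM.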

Compound 4, half-maximal inhibitory concentration: 28300 nM
Compound 4: middle estimate off by 1.1-fold (0.05 log units), on the low side; the measured number falls inside the stated range.
By their numbers in this assay, from the lowest: compound 1; then compounds 2 and 4 (each within the scatter of the next); then compound 3.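

In this assay, among the compounds shown here, the pair of compound 3 and compound 4 gives the first reading of a single edit, since no two earlier compounds differed in one place only. Turning the methoxy on this oxygen on an aromatic ring into a hydroxy gives a 2.2-fold lower number from compound 3 to compound 4 (0.33 log units; beyond the scatter), a modest step but one beyond the scatter, so this small change is enough on its own to make the compound more toxic to the cells, with everything else in the structure held the same. Nothing in the data shown explains why the number moves in this direction.

Going by these compounds, with only hydrogen and methyl compared on this oxygen, it remains open how a longer chain such as ethyl, or a chain ending in an amine, would change the number in this position. On these data alone, it is also open whether the same swap from methoxy to hydroxy at the other methoxy groups of compound 4 would give a step of similar size and direction, or whether this result holds for this one oxygen only.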